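This account rests on a few compounds, and the source may have more. Where it says the series, first, only, none or still open, it means among the compounds named here.

Among the measured compounds shown here, compound 2 `CCCCCCCCCCc1ccc(-c2noc([C@@H]3CCNC3)n2)cc1` has the higher number of the two compounds measured so far: in an assay on HeLa cells for inhibition of sphingosine-1-phosphate transporter SPNS2 (Mus musculus), read by LC-MS, tested at 2 uM (on this read-out higher numbers stand for more inhibition at the one concentration tested (going by the name of the read-out) and lower numbers for less inhibition), compound 2 gives 62%, while compound 1 `CCCCCCCCCCc1ccc(-c2noc(CC3CCNC3)n2)cc1` gives 44%. For the measured compounds named here, the only measured step, a number 18 percentage points higher from compound 1 to compound 2 (beyond the scatter), exchanged (pyrrolidin-3-yl)methyl for pyrrolidin-3-yl on an aromatic carbon, so the amine-bearing ring attached directly to the core gave a higher number than the same ring set one carbon further out. Compound 3 `CCCCCCCCCCc1ccc(-c2noc([C@H]3CCC[C@@H](N)C3)n2)cc1` alters that same position again, but by a different kind of change: 3-aminocyclohexyl in place of pyrrolidin-3-yl on an aromatic carbon. Going by the values given here, the one step in hand bears on it only loosely, since it concerned the spacing of the ring rather than its size, and it was modest. A step no larger than that, in either direction, is therefore expected, a number 7 percentage points lower from compound 2 to compound 3 (within the scatter), and compound 3 is estimated at 55%, between 30% and 80%.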

Compound 3, a percentage reported as inhibition, at one concentration (the size of the read-out at that concentration, not a potency): 29%
Compound 3: the middle estimate sits 26 percentage points above what was measured; the measured number lies below the stated range.
By their numbers in this assay, from the lowest: compound 3; then compound 1; then compound 2.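

In this assay, the group on the aromatic carbon of the shared core matters beyond its spacing: 3-aminocyclohexyl in place of pyrrolidin-3-yl gives a number 33 percentage points lower from compound 2 to compound 3 (beyond the scatter), a large step. The same group in place of (pyrrolidin-3-yl)methyl gives a number 15 percentage points lower from compound 1 to compound 3 (beyond the scatter), so the six-membered ring of carbon only, with its nitrogen outside the ring, stands below both compounds carrying the five-membered ring with its nitrogen inside. Nothing available explains these differences.

The change from compound 2 to compound 3 alters ring size, the place of the nitrogen and the defined stereocentres together, so these compounds cannot separate their contributions. On these data alone, it remains open how a piperidin-3-yl group, with the nitrogen back inside a six-membered ring, or the other stereoisomers of 3-aminocyclohexyl and pyrrolidin-3-yl would read here.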